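Chloro for fluoro on the aryl arm of compound 3

This account rests on a few compounds, and the source may have more. Where it says the series, first, only, none or still open, it means among the compounds named here.

The three measured compounds share one core and differ only in the group attached to it. Compound 1 `Brc1cn2ccnc2c(-c2ccc3ncn(C4CCCCC4)c3c2)n1` carries a bromo there, compound 2 `O=Cc1ccc(-c2cn3ccnc3c(-c3ccc4ncn(C5CCCCC5)c4c3)n2)cc1` a 4-formylphenyl and compound 3 `Fc1ccc(-c2cn3ccnc3c(-c3ccc4ncn(C5CCCCC5)c4c3)n2)cc1` a 4-fluorophenyl. In a functional assay on ACHN cells (Homo sapiens) for inhibition, read by sulforhodamine B assay, with a stated time of 48 h, tested at 10 uM (on this read-out lower numbers stand for less inhibition and higher numbers for more inhibition at the one concentration tested (going by the name of the read-out)), compound 1 gives 11.5%, compound 2 gives 11.6% and compound 3 gives 9.02%. Compound 3 thus sits within the scatter of both neighbours: the step of a number 2.5 percentage points lower from compound 1 to compound 3 (within the scatter) and the step of a number 2.6 percentage points lower from compound 2 to compound 3 (within the scatter) are both small, as is the step of a number 0.1 percentage points higher from compound 1 to compound 2 (within the scatter).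

Compound 4 `Clc1ccc(-c2cn3ccnc3c(-c3ccc4ncn(C5CCCCC5)c4c3)n2)cc1` differs from compound 3 in one place: chloro in place of fluoro on an aromatic carbon. For the measured compounds named here, the steps that bear on this are the ones reaching compound 3, namely a number 2.5 percentage points lower from compound 1 to compound 3 (within the scatter) and a number 2.6 percentage points lower from compound 2 to compound 3 (within the scatter); neither moved the read-out beyond the scatter, even though the groups exchanged there were of quite different kind. A swap of one halogen for another at the same position is a smaller change than either of those, so no step beyond the scatter is expected in this assay, in either direction. The estimated step is a number 1 percentage points higher from compound 3 to compound 4 (within the scatter). Compound 4 is therefore expected to give about 10%, with a likely range from 3% to 18%.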

Compound 4, a percentage reported as inhibition, at one concentration (the size of the read-out at that concentration, not a potency): 5.45%
Beside the measured number, compound 4's estimate is 4.6 percentage points above it; low and high end bracket the measured number.
By their numbers in this assay, from the lowest: compounds 4, 3, 1 and 2 (each within the scatter of the next).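

In this assay, chloro in place of fluoro, on an aromatic carbon para to a large group, gives a number 3.6 percentage points lower from compound 3 to compound 4 (within the scatter), so this exchange of one halogen for another does not separate the two compounds. The 4-chlorophenyl group also stays within the scatter of the two other groups at this place, with a number 6.2 percentage points lower from compound 2 to compound 4 (within the scatter) and a number 6.1 percentage points lower from compound 1 to compound 4 (within the scatter). Compound 4 therefore adds a fourth group that cannot be told apart from bromo, 4-formylphenyl or 4-fluorophenyl in this read-out, and these four compounds show no order among the groups at this position; nothing at hand bears on why the read-out stays this way.

From the compounds shown here alone, it remains open whether an amine or a carboxylic acid on the phenyl ring, in the place of the halogen, would carry the read-out beyond the scatter. Also open, going by these compounds, is whether a piperidine or a longer chain in place of the cyclohexyl group, which is the same in all four compounds, would change the picture in this assay at all.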